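Working notes: carboxyl-bearing substituents, compounds 1 to 3

The source may hold more compounds than are shown below. What is called first, only, known or untested is meant among the compounds shown, and "the series" means these compounds.

Measured so far in an assay on microsomes from brain for inhibition of Fatty-acid amide hydrolase 1 (Rattus norvegicus), read by fluorescence and HPLC, with a stated time of 60 min; on this read-out higher numbers stand for weaker inhibition and lower numbers for stronger inhibition:
compound 1, `CCCCCCCCc1ccc(OCC(=O)Cn2nnc(-c3ccc(Cl)cc3)n2)cc1`: compound 1 gives 35 nM
compound 2, `CCCCCCCCc1ccc(OCC(=O)Cn2nnc(CCC(=O)O)n2)cc1`: compound 2 gives 30 nM

Compound 2 stands at the lowest of the two numbers, but its nearest neighbour is compound 1 and the step of a 1.2-fold lower number from compound 1 to compound 2 (0.07 log units; within the scatter) is within the scatter, so no order between the two can be claimed. Compound 3, `CCCCCCCCc1ccc(OCC(=O)Cn2nnc(-c3cccc(C(=O)O)c3)n2)cc1`, differs from compound 2 by 3-carboxyphenyl in place of 2-carboxyethyl on an aromatic carbon. Going by the values given here, the one measured step that bears on this change is a 1.2-fold lower number from compound 1 to compound 2 (0.07 log units; within the scatter), in which a 4-chlorophenyl gave way to a 2-carboxyethyl without a shift beyond the scatter; compound 3 carries both an aromatic ring and a carboxylic acid at the same position, so the two measured compounds bracket it rather than point in a direction. No step beyond the scatter is therefore expected in this assay for compound 3, that is no change at the digits printed from compound 2 to compound 3 (within the scatter). The estimate for compound 3 in this assay is 30 nM, with a range from 10 nM to 100 nM.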

Compound 3, half-maximal inhibitory concentration: 36 nM
The estimate for compound 3 lay 1.2-fold (0.08 log units) below the measured number; the range from low to high includes it.
By their numbers in this assay, from the lowest: compounds 2, 1 and 3 (each within the scatter of the next).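

In this assay, the step of a 1.2-fold higher number from compound 2 to compound 3 (0.08 log units; within the scatter) and the step of a 1.0-fold higher number from compound 1 to compound 3 (0.01 log units; within the scatter) both lie within the scatter, so 3-carboxyphenyl, with 9 heavy atoms and one six-membered aromatic ring, reads alike with both the 2-carboxyethyl, with 5 heavy atoms and no ring, and the 4-chlorophenyl. Going by these compounds alone, on this aromatic carbon of the five-membered aromatic ring with 4 nitrogen, the three compounds now separate neither a ring from an open chain nor a carboxylic acid from a chlorine: a ring without the acid, a chain with the acid and a ring with the acid all fall within the scatter of one another, and no compound goes against this within the set. Nothing measured here accounts for this sameness of the numbers.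

Still open, going by these compounds, is whether any group at this carbon moves the number beyond the scatter, for instance an amine, a methyl group or a carboxylic acid on a longer chain than 2-carboxyethyl. On these data alone, since the three compounds share one core, it is also open whether the same sameness would hold if the core itself were changed.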